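Swapping the nitro for a chloro on the pendant aryl ring

The source may hold more compounds than are shown below. What is called first, only, known or untested is meant among the compounds shown, and "the series" means these compounds.

Measured compounds in a functional assay for inhibition, tested at 100 ug/mL; on this read-out higher numbers stand for a stronger effect at the one concentration tested and lower numbers for a weaker effect:
compound 1, `COc1ccc(-c2cc(-c3cc(C(C)C)c(O)cc3C)[nH]c(=O)c2C#N)c(OC)c1`, gives 58%;
compound 2, `COc1cc(-c2cc(-c3cc(C(C)C)c(O)cc3C)[nH]c(=O)c2C#N)ccc1O`, gives 44%;
compound 3, `Cc1cc(O)c(C(C)C)cc1-c1cc(-c2ccccc2[N+](=O)[O-])c(C#N)c(=O)[nH]1`, gives 37.5%.

Compound 3 holds the lowest of the three numbers. The step of a number 20.5 percentage points lower from compound 1 to compound 3 (beyond the scatter) lies beyond the scatter, and the step of a number 6.5 percentage points lower from compound 2 to compound 3 (within the scatter) lies within it, so only compound 1 stands apart from compound 3. The step to compound 4, `Cc1cc(O)c(C(C)C)cc1-c1cc(-c2ccccc2Cl)c(C#N)c(=O)[nH]1`, changes the same aryl ring: chloro in place of nitro on an aromatic carbon. Going by the values given here, no measured step exchanges these two groups on that ring. Among the compounds with values here, the steps that bear on it, a number 14 percentage points lower from compound 1 to compound 2 (beyond the scatter) and a number 20.5 percentage points lower from compound 1 to compound 3 (beyond the scatter), show that replacing the whole aryl ring moved the read-out by modest amounts, and one of them, from compound 2 to compound 3, stayed within the scatter. A step of a number 2.5 percentage points higher from compound 3 to compound 4 (within the scatter) in this assay is therefore expected, one not beyond the scatter. Compound 4 is estimated at 40%, between 25% and 55%.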

Compound 4, a percentage reported as inhibition, at one concentration (the size of the read-out at that concentration, not a potency): 34%
The estimate for compound 4 lay 6 percentage points above the measured number; measured number inside the range.
By their numbers in this assay, from the lowest: compounds 4, 3 and 2 (each within the scatter of the next); then compound 1.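

The direct exchange of nitro for chloro on this aryl ring gives a number 3.5 percentage points lower from compound 3 to compound 4 (within the scatter) in this assay, so this read-out does not separate the two groups, even though chloro carries fewer heavy atoms and no hydrogen-bond acceptors. The 2-chlorophenyl group also stays level with the 4-hydroxy-3-methoxyphenyl group, at a number 10 percentage points lower from compound 2 to compound 4 (within the scatter), while a number 24 percentage points lower from compound 1 to compound 4 (beyond the scatter) shows that, among the four aryl groups, only the 2,4-dimethoxyphenyl group stands apart from the others. Nothing available here accounts for these results.

On these data alone, whether an amine or a carboxylic acid on this aryl ring would stay level with chloro and nitro remains open. These numbers also give the size of the effect at one concentration, so they leave open whether the compounds differ in potency.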